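Moving the hydroxyl and methoxy groups on a benzylamine arm

The source may report more compounds than this note shows. Statements on the series, on what has been measured and on what is new or still open speak of the compounds shown alone.

Compound 1 `COc1ccc(Cn2c(C(=O)O)c(CNCc3cc(OC)ccc3O)c3ccc(C)cc32)cc1` carries a (2-hydroxy-5-methoxybenzyl)amino arm on its core. In a functional assay on Bel-7402 cells (Homo sapiens) for antiproliferative activity, read by MTT assay, with a stated time of 72 h (on this read-out lower numbers stand for stronger inhibition and higher numbers for weaker inhibition), compound 1 reaches no number but only a limit, > 50000 nM. Compound 2 `COc1ccc(Cn2c(C(=O)O)c(CNCc3cccc(OC)c3)c3ccc(C(F)(F)F)cc32)cc1`, a related compound with a trifluoromethyl group in place of the methyl, likewise gives only a limit in this assay, > 50000 nM. Both results sit at the limit of > 50000 nM in this assay, at which 2 of the 2 values shown sit, so compound 1 stands at the limit and nothing measured here is more potent or weaker than it in a known way.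

Compound 3 `COc1ccc(Cn2c(C(=O)O)c(CNCc3ccc(O)c(OC)c3)c3ccc(C)cc32)cc1` differs from compound 1 in one place: 4-hydroxy-3-methoxyphenyl in place of 2-hydroxy-5-methoxyphenyl on a saturated chain carbon bound to an amine nitrogen. Going by the values given here, since no step between measured compounds is known, the expectation rests on the shared limit alone; for this assay the step that the limit leaves unreadable from compound 1 to compound 3 is expected to stay within the scatter, with no gain in potency. Compound 3 is therefore estimated at 60000 nM, most likely again reported only as a limit, within 20000 nM to 200000 nM.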

Compound 3, half-maximal inhibitory concentration: 13300 nM
Compound 3: the middle estimate sits 4.5-fold (0.65 log units) above what was measured; the measured number lies below the stated range.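

Moving only the hydroxyl and methoxy groups, from 2-hydroxy-5-methoxyphenyl to 4-hydroxy-3-methoxyphenyl, leaves the atoms unchanged, yet in this assay this gives an at least 3.7-fold lower number from compound 1 to compound 3 (0.57 log units; beyond the scatter). This shows that activity at this place, on a saturated chain carbon bound to an amine nitrogen, depends on how these two groups are arranged on the ring, and not merely on their presence. The step is a minimum and its true size is unknown, since compound 1 gives only a limit, and the earlier compounds alone offered no measured number to compare: the limit of > 50000 nM in this assay, at which 2 of the 3 values shown sit.

Both groups moved in the same step, so the compounds shown do not tell whether the hydroxyl or the methoxy group accounts for the gain. From the compounds shown here alone, how a chlorine or a fluorine on this ring, or a longer chain on the amine nitrogen, would read also remains open.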